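Swapping a substituent on the amine nitrogen of compound 1

The source may hold more compounds than are shown below. What is called first, only, known or untested is meant among the compounds shown, and "the series" means these compounds.

Compound 1, with the structure `CCOC(=O)C1=C(N/C=N/c2nnc(S(N)(=O)=O)s2)Nc2[nH]nc(C)c2C1c1ccc(N(C)C)cc1`, was tested in a functional assay on HeLa cells (Homo sapiens) for inhibition, read by MTT assay, with a stated time of 48 h (on this read-out higher numbers stand for weaker inhibition and lower numbers for stronger inhibition), and gives 26300 nM. Of the three compounds measured, this is the highest number: compound 2, `CCOC(=O)C1=C(N/N=C(/Cl)C#N)Nc2[nH]nc(C)c2C1c1ccc(N(C)C)cc1`, is nearest with 26200 nM, and compound 3, `CCOC(=O)C1=C(N)Nc2[nH]nc(C)c2C1c1ccc(N(C)C)cc1`, is furthest with 6220 nM. Two steps describe this small set. From compound 1 to compound 2, where one substituent on the amine nitrogen is exchanged for another, the change is a 1.0-fold lower number from compound 1 to compound 2 (0.00 log units; within the scatter). From compound 1 to compound 3, where the substituent is removed altogether and a hydrogen atom stands there instead, the change is a 4.2-fold lower number from compound 1 to compound 3 (0.63 log units; beyond the scatter), and likewise a 4.2-fold lower number from compound 2 to compound 3 (0.62 log units; beyond the scatter) from compound 2 to compound 3.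

Compound 4, `CCOC(=O)C1=C(N/N=C(/C(=O)Br)c2ccc(Cl)cc2)Nc2[nH]nc(C)c2C1c1ccc(N(C)C)cc1`, has not yet been measured. It differs from compound 1 in a single place: a group of 12 heavy atoms (8 carbon, 1 nitrogen, 1 oxygen, 1 chlorine, 1 bromine; one six-membered aromatic ring of carbon only) in place of a group of 11 heavy atoms (3 carbon, 4 nitrogen, 2 oxygen, 2 sulfur; one five-membered aromatic ring with 3 hetero atoms), on an amine nitrogen. Among the measured compounds shown here, the closest precedent is the exchange of one substituent for another, which gave a 1.0-fold lower number from compound 1 to compound 2 (0.00 log units; within the scatter). Keeping a substituent on that nitrogen has so far left the number where it was; only removing it has lowered it. Compound 4 is therefore expected to show a 1.2-fold lower number from compound 1 to compound 4 (0.08 log units; within the scatter), a step no larger than the scatter. For compound 4 the estimated value is 22000 nM, with a range from 8000 nM to 60000 nM.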

Compound 4, half-maximal inhibitory concentration: 49300 nM
The estimate for compound 4 lay 2.2-fold (0.35 log units) below the measured number; the range from low to high includes it.
By their numbers in this assay, from the lowest: compound 3; then compounds 2, 1 and 4 (each within the scatter of the next).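

A third kind of substituent on this amine nitrogen now sits with the first two. A group with a six-membered aromatic ring of carbon only takes the place of one with a five-membered aromatic ring with 3 hetero atoms, and the result is a 1.9-fold higher number from compound 1 to compound 4 (0.27 log units; within the scatter), while the comparison with the group of 5 heavy atoms, which has no ring, gives a 1.9-fold higher number from compound 2 to compound 4 (0.27 log units; within the scatter). Among the compounds shown here, the gap to the unsubstituted amine is clear, at a 7.9-fold higher number from compound 3 to compound 4 (0.90 log units; beyond the scatter), so across these four compounds the one divide beyond the scatter lies between a hydrogen atom and any of the three groups, with weaker inhibition on the substituted side and no compound going against it. Why the hydrogen atom stands apart from these groups is not explained by any measurement at hand.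

On these data alone, whether a single methyl group or an acetyl group on that nitrogen would behave like the three larger groups, or still like the hydrogen atom, stays open. The parts of the entering group also remain unseparated, since its chlorine, bromine and carbonyl arrive together, and a group holding the aromatic ring alone would be needed to tell them apart.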